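Para Substituent Swap on a Sulfonamide Series: Chloro to Methoxy

The source may hold more compounds than are shown below. What is called first, only, known or untested is meant among the compounds shown, and "the series" means these compounds.

Measured compounds:
- Compound 1, `O=S(=O)(NCCCNc1nccc(-c2c(-c3cccc(F)c3)nc3sccn23)n1)c1ccccc1`, 6850 nM
- Compound 2, `O=S(=O)(NCCCNc1nccc(-c2c(-c3cccc(F)c3)nc3sccn23)n1)c1ccc(Cl)cc1`, 8450 nM

Both compounds share one core and differ only at the far end of the sulfonamide. In a functional assay on SK-MEL-28 cells (Homo sapiens) for cytotoxicity, read by MTT assay (on this read-out lower numbers stand for stronger inhibition and higher numbers for weaker inhibition), compound 1 gives 6850 nM, and compound 2 gives 8450 nM. Compound 2 holds the higher of the two numbers, yet the step between them is a 1.2-fold higher number from compound 1 to compound 2 (0.09 log units; within the scatter), so the two values cannot be told apart.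

Compound 3, `COc1ccc(S(=O)(=O)NCCCNc2nccc(-c3c(-c4cccc(F)c4)nc4sccn34)n2)cc1`, is not yet measured. Compared with compound 2 it carries methoxy in place of chloro on an aromatic carbon. Within the data shown here, the only step seen so far, a 1.2-fold higher number from compound 1 to compound 2 (0.09 log units; within the scatter), shows that adding a chloro at that position left the number unchanged within the scatter. Nothing is known about a methoxy at that position. The expectation is therefore a step of a 1.1-fold lower number from compound 2 to compound 3 (0.05 log units; within the scatter), meaning no change beyond the scatter. Compound 3 is estimated at 7500 nM, with a range from 3500 nM to 16000 nM.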

Compound 3, half-maximal inhibitory concentration: 8980 nM
The estimate for compound 3 lay 1.2-fold (0.08 log units) below the measured number, and the stated range covers the measured number.
By their numbers in this assay, from the lowest: compounds 1, 2 and 3 (each within the scatter of the next).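

In this assay, replacing the chloro with a methoxy on this aromatic carbon, para to a large group, gives a 1.1-fold higher number from compound 2 to compound 3 (0.03 log units; within the scatter). The methoxy brings two heavy atoms and a hydrogen-bond acceptor where the chloro had one heavy atom and no acceptor, yet the two compounds cannot be told apart. Set against the plain hydrogen of compound 1, the methoxy gives a 1.3-fold higher number from compound 1 to compound 3 (0.12 log units; within the scatter), so hydrogen, chloro and methoxy at this position all read the same within the scatter, and no measurement at hand explains this.

As far as these compounds go, it remains open whether any group here can move the number beyond the scatter, for example an amine or a carboxylic acid. From the compounds shown here alone, it also remains open whether the chloro-to-methoxy swap would read the same on a different core.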